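The source may hold more compounds than are shown below. What is called first, only, known or untested is meant among the compounds shown, and "the series" means these compounds.

Compound 1 `CC(C)Cn1c(=O)n(C)c(=O)c2nc(SCCCCO)c(Cc3cccc4ccccc34)nc21` gives the lowest number among the measured values in a functional assay on Raji cells (Homo sapiens) for inhibition, read by MTT assay, with a stated time of 96 h (on this read-out higher numbers stand for an effect only at larger amounts of compound and lower numbers for an effect already at smaller amounts), namely 37 nM. Compound 3 `CC(C)Cn1c(=O)n(C)c(=O)c2nc(CCCCO)c(Cc3cccc4ccccc34)nc21` gives 285 nM, and the step of a 7.7-fold higher number from compound 1 to compound 3 (0.89 log units; beyond the scatter) is modest. Compound 2 `CC(C)Cn1c(=O)n(C)c(=O)c2nc(C(=O)NCCCO)c(Cc3cccc4ccccc34)nc21` gives > 10000 nM, which is a limit of the assay and not a number (the limit of > 10000 nM in this assay, at which 1 of the 3 values shown sits). The steps of an at least 270-fold higher number from compound 1 to compound 2 (2.43 log units; beyond the scatter) and an at least 35-fold lower number from compound 2 to compound 3 (1.54 log units; beyond the scatter) are large. Compound 4 `CC(C)Cn1c(=O)n(C)c(=O)c2nc(-c3[nH]nnc3CCCO)c(Cc3cccc4ccccc34)nc21` differs from compound 1 in one place: 4-(3-hydroxypropyl)-1H-1,2,3-triazol-5-yl in place of (4-hydroxybutyl)sulfanyl on an aromatic carbon. Both measured changes at this carbon raise the number, the carbamoyl far more than the plain chain. Compound 4 is therefore expected to give a higher number than compound 1, with the step of an 81-fold higher number from compound 1 to compound 4 (1.91 log units; beyond the scatter) expected to fall between the two measured steps. Compound 4 is estimated at 3000 nM, within a range from 500 nM to 20000 nM.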

Compound 4, half-maximal effective concentration: 6020 nM
Compound 4: the middle estimate sits 2.0-fold (0.30 log units) below what was measured; the range from low to high includes it.
By their numbers in this assay, from the lowest: compound 1; then compound 3; then compound 4. At a limit, above all of these: compound 2.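

In this assay, a five-membered aromatic ring at this carbon gives a 160-fold higher number from compound 1 to compound 4 (2.21 log units; beyond the scatter), and measured against the plain chain it still gives a 21-fold higher number from compound 3 to compound 4 (1.32 log units; beyond the scatter). The loss is therefore not confined to the carbamoyl: all three groups shown in place of (4-hydroxybutyl)sulfanyl raise the number. Against the carbamoyl, the data give only an at least 1.6-fold lower number from compound 2 to compound 4 (0.22 log units; that floor lies within the scatter), and the true size of this step cannot be read. The value of compound 2 is a limit of the assay and not a number: the limit of > 10000 nM in this assay, at which 1 of the 4 values shown sits.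

The compounds shown leave open whether an oxygen or an amine nitrogen could replace the sulfur of compound 1 with the chain kept. They also leave open how an amine or a carboxylic acid would compare with the hydroxyl on that chain.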